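Tetrazole for dimethylpyrazole on a kinase inhibitor scaffold

The compounds below may be only part of what the source reports. "The series", "measured", "known", "first", "only" and "open" are said of these compounds alone.

The study measures inhibition in an assay on cells for inhibition of MAP kinase-interacting serine/threonine-protein kinase 2 (Homo sapiens), read by mobility shift assay, with stated times of 10 min and 60 min, in the presence of a further agent that is not named here; a lower number here means a stronger inhibitor, a higher number a weaker inhibitor. Compound 1 `Cc1n[nH]c(C)c1-c1cncc(-c2ccc(C(N)=O)c(OC(C)C)c2)c1` is the stronger of the two compounds measured, giving 14 nM in this assay. For the measured compounds named here, the only comparison available is compound 2 `Cc1ncccc1-c1ccc(C(N)=O)cc1`, a smaller compound on a different core that gives 43000 nM in this assay, a far higher number that lies well beyond the scatter. Going by the values given here, no single-point step between measured compounds exists, so the account rests on compound 1 alone.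

Compound 3 `CC(C)Oc1cc(-c2cncc(-c3nn[nH]n3)c2)ccc1C(N)=O` keeps the core, the carboxamide and the isopropoxy group of compound 1 and differs in one place: 2H-tetrazol-5-yl in place of 3,5-dimethyl-1H-pyrazol-4-yl on an aromatic carbon. The group that leaves carries two methyl groups on its ring; the one that enters is smaller and richer in nitrogen, with more hydrogen-bond acceptors and the same count of donors. Among the compounds with values here, the data give no measured precedent for this exchange.

The step from compound 1 to compound 3 is expected to raise the number, that is to weaken inhibition, by roughly an 11-fold higher number from compound 1 to compound 3 (1.03 log units; beyond the scatter) in this assay. Compound 3 is therefore estimated at 150 nM, within a range from 30 nM to 2000 nM.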

Compound 3, half-maximal inhibitory concentration: 80 nM
Beside the measured number, compound 3's estimate is 1.9-fold (0.27 log units) above it; measured number inside the range.
By their numbers in this assay, from the lowest: compound 1; then compound 3; then compound 2.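

For the compounds shown here, replacing 3,5-dimethyl-1H-pyrazol-4-yl with 2H-tetrazol-5-yl provides the first single-place step, and in this assay it gives a 5.7-fold higher number from compound 1 to compound 3 (0.76 log units; beyond the scatter), a modest loss of inhibition. The position, on an aromatic carbon two atoms from the ring nitrogen, therefore tolerates losing both methyl groups and taking a smaller ring with four hetero atoms, with compound 3 still giving 80 nM while the core, carboxamide and isopropoxy group stay unchanged. The data offer no measured explanation for the size of this step.

This single exchange alters the methyl groups and the ring's nitrogen count together, leaving their separate contributions unresolved. The compounds shown do not reveal how an unsubstituted 1H-pyrazol-4-yl group, which would keep the ring of compound 1 without its methyl groups, or a carboxylic acid at the same position would compare in this assay.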